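Swapping the pyrrolidinyl sulfonamide for a hydroxyacetyl piperidine

A few compounds are considered here, and "the series" means these few. Any claim that something is new, unique, unknown or untested is made for them only; others in the source may bear on it.

Measured so far:
compound 1 `CN1CCN(c2ccc(Nc3ncc4nc(Nc5ccc(F)cc5)n(CCNS(=O)(=O)C5CC5)c4n3)cc2)CC1`, a functional assay on A-431 cells (Homo sapiens) for antiproliferative activity, read by MTT assay, with a stated time of 72 h; a lower number here means a stronger inhibitor, a higher number a weaker inhibitor: "not determined" (no result reported)
compound 2 `CC(=O)Nc1cccc(-n2c(Nc3ccc(F)cc3)nc3cnc(Nc4ccc(N5CCN(C)CC5)cc4)nc32)c1`, this assay: "not determined" (no result reported)
compound 3 `CN1CCN(c2ccc(Nc3ncc4nc(Nc5ccc(F)cc5)n([C@@H]5CCN(S(=O)(=O)C6CC6)C5)c4n3)cc2)CC1`, this assay: > 10000 nM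

Among the compounds with values here, three compounds share a core, yet only one carries a number of any kind in this assay. Compound 1 and compound 2 have no result reported. Compound 3 stands alone, and what it shows is not a number but a limit: in this assay compound 3 gives > 10000 nM, a limit of the assay. That is the whole of the evidence, and it is summarised by the limit of > 10000 nM in this assay, at which 1 of the 3 values shown sits.

Compound 4 `CN1CCN(c2ccc(Nc3ncc4nc(Nc5ccc(F)cc5)n([C@H]5CCCN(C(=O)CO)C5)c4n3)cc2)CC1` keeps everything except the group on the aromatic nitrogen. The change is 1-((hydroxymethyl)carbonyl)piperidin-3-yl in place of 1-(cyclopropylsulfonyl)pyrrolidin-3-yl on an aromatic nitrogen.

Within the data shown here, with no step between measured compounds to lean on, and compound 3 sitting at a limit, the expected size of the step from compound 3 to compound 4 in this assay cannot be anchored in either direction; the account expects it to stay near the scatter, with the result for compound 4 more likely to be another limit than a clear number. The expected step is an at least 1.1-fold lower number from compound 3 to compound 4 (0.04 log units; that floor lies within the scatter). Compound 4 is estimated at 9000 nM, in the range from 2500 nM to 30000 nM.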

Compound 4, half-maximal inhibitory concentration: 3000 nM
Beside the measured number, compound 4's estimate is 3.0-fold (0.48 log units) above it; the range from low to high includes it.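

Compound 4 is the first of these compounds to give a number rather than a limit in this assay, which shows that a substituent on this aromatic nitrogen is compatible with a measurable antiproliferative read-out. Placing 1-((hydroxymethyl)carbonyl)piperidin-3-yl in place of 1-(cyclopropylsulfonyl)pyrrolidin-3-yl gives an at least 3.3-fold lower number from compound 3 to compound 4 (0.52 log units; beyond the scatter), so this change matters at this position even though the shared core stays the same. The value of compound 3 is a limit and not a number, so the step can be given only as a floor, with its true size unknown: the limit of > 10000 nM in this assay, at which 1 of the 4 values shown sits.

The change alters the ring size, the group on the ring nitrogen and the sulfonyl-to-carbonyl link all at once, so the compounds shown do not say which of these accounts for the step. From the compounds shown here alone, it also stays open whether a 1-((hydroxymethyl)carbonyl)pyrrolidin-3-yl group, which would separate the five-membered ring from the six-membered one, or a piperidin-3-yl group bearing a plain acetyl or a free amine on its ring nitrogen, would move the number further in either direction.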